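The compounds below may be only part of what the source reports. "The series", "measured", "known", "first", "only" and "open" are said of these compounds alone.

Measured so far in a functional assay on the whole organism (Tail, strain ICR) with Mus musculus as the target, in the tail flick test, with a stated time of 120 min, at a dose of 25 umol/kg by the oral route; on this read-out lower numbers stand for a weaker effect and higher numbers for a stronger effect at the one dose given:

Compound 1, `C[C@@H](O)[C@H](NC(=O)CN(c1nc(Cl)nc2[nH]cnc12)C1CC1)C(=O)OCc1ccccc1`: 30.7%
Compound 2, `NCCCC[C@H](NC(=O)CN(c1nc(Cl)nc2[nH]cnc12)C1CC1)C(=O)OCc1ccccc1`: 16.8%
Compound 3, `C[C@@H](O)[C@H](NC(=O)CN(c1nc(Cl)nc2[nH]cnc12)C1CC1)C(=O)O`: 37.6%

All three share the same amide-linked core and differ only in two places. The first difference is on the saturated chain carbon bound to the amide-type nitrogen and the carbonyl carbon, (4-aminobutyl in place of 1-hydroxyethyl on a saturated chain carbon bound to an amide-type nitrogen and a carbonyl carbon). Across this change the read-out moved a number 13.9 percentage points lower from compound 1 to compound 2 (beyond the scatter). The second difference is the ester oxygen, (hydrogen in place of benzyl on an oxygen next to a carbonyl group), and here the read-out moved a number 6.9 percentage points higher from compound 1 to compound 3 (within the scatter), so compound 1 and compound 3 cannot be told apart on this read-out.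

The not yet measured compound 4, `NCCCC[C@H](NC(=O)CN(c1nc(Cl)nc2[nH]cnc12)C1CC1)C(=O)O`, carries the acid of compound 3 together with the side chain of compound 2. Its relation to compound 3 is 4-aminobutyl in place of 1-hydroxyethyl on a saturated chain carbon bound to an amide-type nitrogen and a carbonyl carbon, the same change as between compound 1 and compound 2, at a place described in identical words.

Among the compounds with values here, with only one prior instance of this change, the expectation for compound 4 rests on compound 3 at 37.6% and on the step seen once before, a number 13.9 percentage points lower from compound 1 to compound 2 (beyond the scatter), and so a step of about a number 13.6 percentage points lower from compound 3 to compound 4 (beyond the scatter) is estimated. On these data alone, compound 4 is therefore expected to give roughly 24%, with a likely range from 12% to 36%, the width reflecting that the transfer of a single step onto a different ester oxygen is untested here.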

Compound 4, a percentage reported as activity, at one dose (the size of the read-out at that dose, not a potency): 16.4%
For compound 4 the middle estimate is 7.6 percentage points above the measured one, and the stated range covers the measured number.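

In this assay, 4-aminobutyl in place of 1-hydroxyethyl again lowers the read-out on the free acid, a number 21.2 percentage points lower from compound 3 to compound 4 (beyond the scatter), and this step does not differ from the one seen on the benzyl ester: the same change on two cores in this assay, a number 13.9 percentage points lower (beyond the scatter) from compound 1 to compound 2 and a number 21.2 percentage points lower (beyond the scatter) from compound 3 to compound 4, 7.3 percentage points apart, within the scatter of two such steps

Hydrogen in place of benzyl on the oxygen gives no readable change with 4-aminobutyl on the chain, a number 0.4 percentage points lower from compound 2 to compound 4 (within the scatter), and this agrees with what was seen with 1-hydroxyethyl: the same change on two cores in this assay, a number 6.9 percentage points higher (within the scatter) from compound 1 to compound 3 and a number 0.4 percentage points lower (within the scatter) from compound 2 to compound 4, 7.3 percentage points apart, within the scatter of two such steps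

These two pairs show that, within this small set, each change carried over between the two cores, but the agreement rests on a single instance per core at one dose and one time point, so it gives no potency and does not extend to any other core.

The compounds shown leave open how a chain ending in a carboxylic acid, or a shorter amine chain such as 2-aminoethyl, would compare with 4-aminobutyl and 1-hydroxyethyl at this place. They also leave open whether an ethyl ester would track the benzyl ester and the free acid in the same way.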